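Compound 3 to compound 4: swapping the 4-bromophenyl group

The source may hold more compounds than are shown below. What is called first, only, known or untested is meant among the compounds shown, and "the series" means these compounds.

In a functional assay on WI-38 VA13 cells (Homo sapiens) for cytotoxicity (on this read-out higher numbers stand for an effect only at larger amounts of compound and lower numbers for an effect already at smaller amounts), compound 1 `O=C(Nc1ccc2nc(NC(=O)C3CCCCC3)sc2c1)c1ccccc1Cl` gives 0.025 ug/mL and compound 2 `O=C(Nc1ccc2nc(NC(=O)C3CCCCC3)sc2c1)c1ccccc1C(F)(F)F` gives 0.024 ug/mL. The step between them is a 1.0-fold lower number from compound 1 to compound 2 (0.02 log units; within the scatter).

Compound 3 `O=C(Nc1ccc2nc(NC(=O)C3CCCCC3)sc2c1)c1ccc(Br)cc1` gives > 4 ug/mL in this assay, and this is a limit, not a number.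

Compound 4 `CCC(C)(C)C(=O)Nc1ccc2nc(NC(=O)C3CCCCC3)sc2c1` carries 1,1-dimethylpropyl in place of 4-bromophenyl on a carbonyl carbon.

Two measured steps change the group at this carbonyl carbon: an at least 160-fold higher number from compound 1 to compound 3 (2.20 log units; beyond the scatter) and an at least 160-fold higher number from compound 2 to compound 3 (2.22 log units; beyond the scatter). Both are large, so the read-out in this assay can move widely with this group. Among the compounds with values here, neither step involves 1,1-dimethylpropyl, and no measured compound has a group without a ring at this place, so the size of the change remains uncertain. A shift towards a lower number is expected, but only part of the way back to the values of compound 1 and compound 2.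

The estimated change is an at least 10-fold lower number from compound 3 to compound 4 (1.00 log units; beyond the scatter).

For compound 4 the expected value is 0.4 ug/mL, with an estimated range of 0.03 ug/mL to 5 ug/mL.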

Compound 4, half-maximal effective concentration: 1 ug/mL
Beside the measured number, compound 4's estimate is 2.5-fold (0.40 log units) below it; the measured number falls inside the stated range.
By their numbers in this assay, from the lowest: compounds 2 and 1 (each within the scatter of the next); then compound 4. At a limit, above all of these: compound 3.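

In this assay, within the data shown here, 1,1-dimethylpropyl, the only group without a ring at this carbonyl carbon, gives a lower number than 4-bromophenyl: an at least 4.0-fold lower number from compound 3 to compound 4 (0.60 log units; beyond the scatter). An aromatic ring at this place is therefore not needed for an effect at smaller amounts, yet 1,1-dimethylpropyl does not match the two groups with the lowest numbers, as a 40-fold higher number from compound 1 to compound 4 (1.60 log units; beyond the scatter) and a 42-fold higher number from compound 2 to compound 4 (1.62 log units; beyond the scatter) show. The first step has only a lower bound because compound 3 carries a limit and not a number: the limit of > 4 ug/mL in this assay, at which 1 of the 4 values shown sits.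

On these data alone, it remains open whether the branching of 1,1-dimethylpropyl or simply the absence of a ring sets its place. A cyclohexyl group or a straight pentyl chain at this carbonyl carbon would address that question.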